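Swapping the aryl group on the triazole: compound 3

The source may hold more compounds than are shown below. What is called first, only, known or untested is meant among the compounds shown, and "the series" means these compounds.

Compound 2 `CC1(C)[C@H]2CC[C@]1(C)N(Cc1cn(-c3cccc(O)c3)nn1)C(=O)C2` is one of two compounds with a measured number here. In a functional assay on PANC-1 cells (Homo sapiens) for inhibition, read by MTT assay, with a stated time of 24 h (on this read-out higher numbers stand for weaker inhibition and lower numbers for stronger inhibition), compound 2 gives 280 nM, the higher of the two. Among the measured compounds shown here, compound 1 `COc1ccccc1-n1cc(CN2C(=O)C[C@@H]3CC[C@@]2(C)C3(C)C)nn1` gives 120 nM in this assay, and the only measured step, a 2.3-fold higher number from compound 1 to compound 2 (0.37 log units; beyond the scatter), shows that changing the aryl group on the triazole nitrogen moves the number by a modest amount.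

Compound 3 `CC1(C)[C@H]2CC[C@]1(C)N(Cc1cn(-c3ccc(C#N)cc3)nn1)C(=O)C2` has not yet been measured. It differs from compound 2 in one place: 4-cyanophenyl in place of 3-hydroxyphenyl on an aromatic nitrogen. For the measured compounds named here, no measured step involves a 4-cyanophenyl group, so the direction of the change is open; the one step available suggests a modest shift in either direction rather than a large one. Compound 3 is therefore expected to give about 200 nM in this assay, with a plausible range from 70 nM to 600 nM, an expected step of a 1.4-fold lower number from compound 2 to compound 3 (0.15 log units; within the scatter).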

Compound 3, half-maximal inhibitory concentration: 250 nM
Compound 3: middle estimate off by 1.3-fold (0.10 log units), on the low side, within the range that was stated.
By their numbers in this assay, from the lowest: compound 1; then compounds 3 and 2 (each within the scatter of the next).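

In this assay, replacing the 3-hydroxyphenyl group, which carries a hydrogen-bond donor, with the 4-cyanophenyl group, which carries none, gives a 1.1-fold lower number from compound 2 to compound 3 (0.05 log units; within the scatter), so this pair of aryl groups on the triazole nitrogen cannot be told apart. Compound 1 still holds the lowest number of the three, with a 2.1-fold higher number from compound 1 to compound 3 (0.32 log units; beyond the scatter) adding a second modest step beyond the scatter, so two quite different aryl groups now both fall short of the 2-methoxyphenyl group. Nothing available here explains these numbers.

The compounds shown leave open whether the methoxy group itself or its place on the ring sets compound 1 apart, as each step changes both the substituent and its place. A 4-methoxyphenyl or 2-hydroxyphenyl group, or a plain phenyl ring, could help separate these possibilities.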